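The source may report more compounds than this note shows. Statements on the series, on what has been measured and on what is new or still open speak of the compounds shown alone.

Compound 1 `CCCCNc1cc(Oc2c(OC)cc3cc(C#N)ccc3c2OC)nc(Nc2ccc(C#N)cc2)n1` carries a butylamino group on its core. In an ADME assay on MT4 cells (Homo sapiens) for cytotoxicity, read by MTT assay, with a stated time of 5 days (on this read-out lower numbers stand for higher toxicity in this test and higher numbers for lower toxicity in this test), compound 1 gives > 125000 nM, and that number is a limit of the measurement rather than a measured point. Compound 2 `COc1cc2cc(C#N)ccc2c(OC)c1Oc1cc(NC2CC2)nc(Nc2ccc(C#N)cc2)n1` differs from compound 1 by a cyclopropyl in place of butyl on a nitrogen on an aromatic ring. In this assay compound 2 also gives > 125000 nM, again a limit and not a number. Among the compounds with values here, the step from compound 1 to compound 2 therefore reads a step that the two limits leave unreadable from compound 1 to compound 2, and the only evidence on this pair is the limit of > 125000 nM in this assay, at which 2 of the 2 values shown sit.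

Compound 3 `COc1cc2cc(C#N)ccc2c(OC)c1Oc1cc(NCCC2=CCCCC2)nc(Nc2ccc(C#N)cc2)n1` is the next case. Compared with compound 1 the change is cyclohex-1-en-1-yl in place of ethyl on a saturated chain carbon, two bonds along the chain from a nitrogen on an aromatic ring. Within the data shown here, the single measured step, from compound 1 to compound 2, bears on this change only loosely, since it too alters the substituent on that nitrogen and gave no readable size. With both measured compounds sitting at the limit, the expectation for compound 3 is that it stays near the same region, so the step of a number no higher from compound 1 to compound 3 (the limit leaves the size open) is estimated as none beyond the scatter. Compound 3 is thus expected to give about 125000 nM in this assay, with a range from 40000 nM to 300000 nM.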

Compound 3, half-maximal cytotoxic concentration: > 125000 nM
Compound 3: a limit, no number (the forecaster's own chance of this, stated with the estimate: 75%); the middle value lies on the limit itself.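

No step among compound 1, compound 2 and compound 3 can be read in this assay, because all three values are limits and not numbers: the limit of > 125000 nM in this assay, at which 3 of the 3 values shown sit.

The compounds shown leave open how far past that limit each half-maximal cytotoxic concentration lies, and so whether changing the substituent on that nitrogen alters it at all.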